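The compounds below may be only part of what the source reports. "The series", "measured", "known", "first", "only" and "open" are said of these compounds alone.

Measured so far:
compound 1, `NC(=O)CN1CCN(c2nc(-c3cccnc3)nc3c2CN(Cc2ccccc2)CC3)CC1`, 100000 nM
compound 2, `Cc1cc(C)c2cc(C#N)c(N3CCN(C(=O)c4ccccn4)CC3)nc2c1`, 100000 nM
compound 3, `Cc1cc(C)c2cc(C#N)c(NCCNC(=O)c3ccccc3)nc2c1`, 100000 nM

In an assay on cells with Cystic fibrosis transmembrane conductance regulator variant F508del (Homo sapiens) as the target, read by fluorescence, with stated times of 24 h and 30 min (a higher number here means that more compound is needed for the effect, a lower number that less compound is needed), compound 1 gives 100000 nM. In this assay compound 2 gives 100000 nM, and in this assay compound 3 gives 100000 nM. Compound 2 therefore stands level with compound 1 and with compound 3 at the digits shown; none of the three is separated from another by more than the usual scatter, so no order among them can be read from these numbers. No pair of these compounds differs in only one place, so no single step between measured compounds is available.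

Compound 4, `Cc1cc(C)c2cc(C#N)c(N3CCN(C(=O)c4ccncc4)CC3)nc2c1`, has not yet been measured in this assay. It differs from compound 2 in one place: pyridin-4-yl in place of pyridin-2-yl on a carbonyl carbon. The two share every other atom and bond, and only the point at which the ring nitrogen sits in the six-membered aromatic ring on the carbonyl carbon is moved.

With the three measured compounds all at the same value, there is nothing among them that would point the step toward either direction. The expectation for the step from compound 2 to compound 4 is therefore a change of no change at the digits printed from compound 2 to compound 4 (within the scatter), that is, none beyond the scatter. Compound 4 is estimated to give 100000 nM in this assay, within a range from 40000 nM to 100000 nM.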

Compound 4, half-maximal effective concentration: 100000 nM
The estimate for compound 4 equals the measured number at the digits printed, within the range that was stated.
By their numbers in this assay, from the lowest: compounds 1, 2, 3 and 4 (each within the scatter of the next).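

In this assay, going by these compounds alone, pyridin-4-yl in place of pyridin-2-yl on a carbonyl carbon gives no change at the digits printed from compound 2 to compound 4 (within the scatter) and is the first step here that changes only one place. The earlier compounds shown here offered no such pair, whereas this one shows that moving the ring nitrogen within this six-membered aromatic ring, on a carbonyl carbon whose other neighbour is an amide-type nitrogen in a ring, leaves compound 4 level with compound 2 at the digits printed. Nothing measured here bears on the reason for this result.

Compounds 2 and 4 leave open whether pyridin-3-yl, cyclohexyl or an aminomethyl group on the same carbonyl carbon would give a different value in this assay at all. With both compounds at one value, the step also does not show whether this position can influence the read-out, or whether a change elsewhere on the shared core, such as replacing the nitrile with a carboxylic acid, would have to come first.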